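Swapping a bicyclic lactam on the piperazine of compound 1

The compounds below may be only part of what the source reports. "The series", "measured", "known", "first", "only" and "open" are said of these compounds alone.

Measured so far:
compound 1, `O=C1CCc2c(cccc2N2CCN(CC(O)COc3ccccc3C(=O)c3ccccc3)CC2)N1` — 2400 nM
compound 2, `O=C1c2ccccc2CN1C1CCN(CC(O)COCc2ccc(C(F)(F)F)cc2)CC1` — 1500 nM

Two compounds have numbers in an assay on isolated protein for inhibition of sodium channel protein type 9 subunit alpha (Mus musculus), read by patch clamp; a higher number here means a weaker inhibitor, a lower number a stronger inhibitor. Compound 1 gives 2400 nM and stands highest of the two, but its nearest neighbour, compound 2, gives 1500 nM, and the gap between them lies within the scatter, so no order can be read from them.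

Compound 3, `O=C(c1ccccc1)c1ccccc1OCC(O)CN1CCN(c2cccc3[nH]c(=O)oc23)CC1`, is not yet measured. It differs from compound 1 in one place: a group of 10 heavy atoms (7 carbon, 1 nitrogen, 2 oxygen; one five-membered aromatic ring with 2 hetero atoms, one six-membered aromatic ring of carbon only) in place of a group of 11 heavy atoms (9 carbon, 1 nitrogen, 1 oxygen; one six-membered non-aromatic ring with 1 hetero atom, one six-membered aromatic ring of carbon only), on an amine nitrogen in a ring, on an amine nitrogen in a ring. Going by the values given here, no measured pair shows this change, so its size is unknown here. Since both groups keep one hydrogen-bond donor and the shared core is untouched, the expected step from compound 1 to compound 3, a 1.2-fold lower number from compound 1 to compound 3 (0.08 log units; within the scatter), is small and not beyond the scatter. Compound 3 is therefore expected to give about 2000 nM in this assay, within a range from 700 nM to 6000 nM.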

Compound 3, half-maximal inhibitory concentration: 31000 nM
Beside the measured number, compound 3's estimate is 16-fold (1.19 log units) below it; measured number above the stated range.
By their numbers in this assay, from the lowest: compounds 2 and 1 (each within the scatter of the next); then compound 3.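

In this assay, the group on an amine nitrogen in a ring turns out to matter: the exchange gives a 13-fold higher number from compound 1 to compound 3 (1.11 log units; beyond the scatter) with the rest of the structure unchanged. The leaving and entering groups each hold the same count of hydrogen-bond donors, so a kept donor count does not by itself preserve the number at this position. Nothing shown here accounts for the size of this step.

Going by these compounds alone, the single pair does not separate the effect of the five-membered aromatic ring from that of its second hetero atom, and compound 2 differs from these compounds in more than one place. On these data alone, how a plain phenyl ring or a carboxylic acid would fare on this nitrogen remains open.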